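One hydroxy added to the core of compound 1

The source may hold more compounds than are shown below. What is called first, only, known or untested is meant among the compounds shown, and "the series" means these compounds.

Measured in a functional assay on A549 cells (Homo sapiens) for cytotoxicity, read by sulforhodamine B assay, with a stated time of 72 h; on this read-out lower numbers stand for stronger inhibition of growth and higher numbers for weaker inhibition of growth:
Compound 1 `C=C1CC[C@@H]2[C@](C)(CCC[C@]2(C)C(=O)OC)[C@H]1CCc1ccc2c(OCc3ccccc3)ccc(OCc3ccccc3)c2c1`: > 5000 nM (a limit)
Compound 2 `C=C1CC[C@@H]2[C@](C)(CCC[C@]2(C)C(=O)OCc2ccccc2)[C@H]1CCc1ccc2c(OCc3ccccc3)ccc(OCc3ccccc3)c2c1`: 6500 nM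
Compound 3 `C=C1[C@H](O)C[C@@H]2[C@](C)(CCC[C@]2(C)C(=O)OC)[C@H]1CCc1ccc2c(OCc3ccccc3)ccc(OCc3ccccc3)c2c1`: > 4900 nM (a limit)

In this assay compound 1 gives only a limit, > 5000 nM. Compound 4 `C=C1CC[C@@H]2[C@](C)(CCC[C@]2(C)C(=O)OC)[C@]1(O)CCc1ccc2c(OCc3ccccc3)ccc(OCc3ccccc3)c2c1` differs from it by one change, hydroxy in place of hydrogen on a saturated ring carbon.

Compound 3 carries the same exchange on a different ring carbon, and this is the closest guide. That change is a step that the two limits leave unreadable from compound 1 to compound 3. Compound 3 also gives only a limit, > 4900 nM. The other measured change, phenyl in place of hydrogen on a saturated chain carbon bound to an oxygen next to a carbonyl group, is a step that the limit leaves unreadable from compound 1 to compound 2. Compound 2 gives a number, 6500 nM, in the same general region.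

No step beyond the scatter is therefore expected, and a further limit is quite likely. The estimated change is a step that the limit leaves unreadable from compound 1 to compound 4. For compound 4 the estimated value is 6000 nM, with an expected range from 3000 nM to 12000 nM.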

Compound 4, concentration for 50% growth inhibition: 12400 nM
Compound 4: the middle estimate sits 2.1-fold (0.32 log units) below what was measured; measured number outside the range, above it.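

In this assay compound 1 gives only a limit, > 5000 nM. The step to compound 4 therefore cannot be read, although compound 4 gives a number, 12400 nM. The compounds shown leave open whether hydroxy in place of hydrogen on a saturated ring carbon changes growth inhibition at all.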